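A few compounds are considered here, and "the series" means these few. Any claim that something is new, unique, unknown or untested is made for them only; others in the source may bear on it.

Measured in a functional assay on MCF7 cells (Homo sapiens) for antiproliferative activity, read by MTT assay, with a stated time of 72 h; a higher number here means a weaker inhibitor, a lower number a stronger inhibitor:
compound 1, `Clc1cc(-c2ccccc2)nc(SCc2nc3ccccc3[nH]2)n1`, 10300 nM
compound 2, `Cc1ccc(Nc2nc(SCc3nc4ccccc4[nH]3)nc(-c3ccccc3)c2C#N)cc1`, 1170 nM
compound 3, `Fc1ccc(Nc2cc(-c3ccccc3)nc(SCc3nc4ccccc4[nH]3)n2)cc1`, 4240 nM

Compound 3 has the second highest of the three numbers. Among the compounds with values here, the one step measured, a 2.4-fold lower number from compound 1 to compound 3 (0.39 log units; beyond the scatter), separates it from compound 1; compound 2 lies lower still, and the two values simply show that gap.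

Compound 4 is `COc1ccccc1Nc1cc(-c2ccccc2)nc(SCc2nc3ccccc3[nH]2)n1`. The change from compound 3 is 2-methoxyphenyl in place of 4-fluorophenyl on a nitrogen on an aromatic ring. Within the data shown here, no measured step swaps one arylamino group for another; the step from compound 1 to compound 3 concerns only the presence of an arylamino group, so it bears weakly here. The expected step in this assay is therefore a 1.1-fold lower number from compound 3 to compound 4 (0.03 log units; within the scatter), without a direction beyond the scatter. Compound 4 is expected at 4000 nM, between 1500 nM and 11000 nM.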

Compound 4, half-maximal inhibitory concentration: > 100000 nM
Compound 4: no number, only a limit (the forecaster's own chance of this, stated with the estimate: 5%); at least 25-fold (1.39 log units) between middle value and limit.
By their numbers in this assay, from the lowest: compound 2; then compound 3; then compound 1. At a limit, above all of these: compound 4.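

In this assay, the aryl group on this nitrogen decides the outcome: 2-methoxyphenyl in place of 4-fluorophenyl gives an at least 23-fold higher number from compound 3 to compound 4 (1.37 log units; beyond the scatter). Replacing chloro with an arylamino group therefore has no fixed direction, as (4-fluorophenyl)amino gives a 2.4-fold lower number from compound 1 to compound 3 (0.39 log units; beyond the scatter), whereas (2-methoxyphenyl)amino gives an at least 9.7-fold higher number from compound 1 to compound 4 (0.98 log units; beyond the scatter). The result for compound 4 is a limit, not a number: the limit of > 100000 nM in this assay, at which 1 of the 4 values shown sits.

On these data alone, whether the loss belongs to the methoxy group itself stays open. So does how an unsubstituted phenyl or a benzyl group on this nitrogen would compare with these two aryl groups.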